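Amide substituent and solubility in the aminopyrazine series

The compounds below may be only part of what the source reports. "The series", "measured", "known", "first", "only" and "open" are said of these compounds alone.

The three measured compounds share a core and differ only in the group on the carbonyl carbon. In a physicochemical assay for solubility, read by HPLC, using the shake flask method, in phosphate buffer, with a stated time of 2 h, at pH 6.5 (on this read-out lower numbers stand for lower solubility and higher numbers for higher solubility), compound 1 `Nc1ncc(-c2ccc(C(=O)N3CCC(N)C3)cc2)nc1-c1ccc(C(F)(F)F)cc1` gives 102000 nM. Compound 2 `Nc1ncc(-c2ccc(C(=O)N3CCC(O)CC3)cc2)nc1-c1ccc(C(F)(F)F)cc1` gives 19000 nM in this assay. Compound 3 `NC(=O)c1ccc(-c2cnc(N)c(-c3ccc(C(F)(F)F)cc3)n2)cc1` gives < 5000 nM in this assay, which is a limit and not a number; it sits at the limit of < 5000 nM in this assay, at which 1 of the 3 values shown sits, so compound 3 stands at the bottom of the measured set with only a bound to its value.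

The steps to compound 3 run downward: an at least 20-fold lower number from compound 1 to compound 3 (1.30 log units; beyond the scatter) and an at least 3.8-fold lower number from compound 2 to compound 3 (0.57 log units; beyond the scatter). The remaining step, a 5.4-fold lower number from compound 1 to compound 2 (0.73 log units; beyond the scatter), sets the two cyclic amides apart from each other.

Compound 4 `Nc1ncc(-c2ccc(C(=O)N3CCC(N)CC3)cc2)nc1-c1ccc(C(F)(F)F)cc1` has not yet been measured in this assay. Its change from compound 3 is 4-aminopiperidin-1-yl in place of amino on a carbonyl carbon. This reverses the direction of the two steps into compound 3, so a large rise in this assay is expected, of the order of the step from compound 1, since compound 4 carries a cyclic amide with a primary amine like compound 1 at 102000 nM. The step is expected to be an at least 16-fold higher number from compound 3 to compound 4 (1.20 log units; beyond the scatter). Compound 4 is estimated at 80000 nM, within 20000 nM to 300000 nM.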

Compound 4, solubility: 88000 nM
Compound 4: the middle estimate sits 1.1-fold (0.04 log units) below what was measured; the range from low to high includes it.
By their numbers in this assay, from the lowest: compound 2; then compounds 4 and 1 (each within the scatter of the next). At a limit, below all of these: compound 3.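

Compound 3 stands at a limit and not a number, so an at least 17-fold higher number from compound 3 to compound 4 (1.24 log units; beyond the scatter) in this assay gives only a bound on the size of this change at the carbonyl carbon: the limit of < 5000 nM in this assay, at which 1 of the 4 values shown sits. The hydroxy-to-amino exchange now supplies a pair with the six-membered ring held constant, which compounds 1 and 2 could not supply since they differ in both the ring and its substituent, and it gives a 4.6-fold higher number from compound 2 to compound 4 (0.67 log units; beyond the scatter). The two amino-bearing rings, 3-aminopyrrolidin-1-yl and 4-aminopiperidin-1-yl, are not told apart on this read-out, with a 1.2-fold lower number from compound 1 to compound 4 (0.06 log units; within the scatter), so the change of ring in this pair leaves no mark beyond the scatter.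

Still open, from the compounds shown here alone, is how the number responds when the ring amino group gives way to a dimethylamino group or a carboxylic acid, or when an open-chain group such as 2-aminoethyl stands on the amide nitrogen in place of the ring. The compounds shown also leave open whether the pattern holds at other pH values, as all of them are read under a single set of conditions in this assay.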